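A few compounds are considered here, and "the series" means these few. Any claim that something is new, unique, unknown or untested is made for them only; others in the source may bear on it.

Measured so far in a functional assay on A549 cells (Homo sapiens) for cytotoxicity, read by MTT assay; a lower number here means a stronger inhibitor, a higher number a weaker inhibitor:
- compound 1 `CC1=NNC(=O)C1C(c1c(-c2ccccc2)[nH]c2ccc(C)cc12)c1c(-c2ccccc2)[nH]c2ccc(Cl)cc12` gives 35000 nM
- compound 2 `COc1ccc2[nH]c(-c3ccccc3)c(C(c3c(-c4ccccc4)[nH]c4ccc(C)cc34)C3C(=O)NN=C3C)c2c1` gives 1800 nM
- compound 3 `CC1=NNC(=O)C1C(c1c[nH]c2ccccc12)c1c(-c2ccccc2)[nH]c2ccc(Cl)cc12` gives 1600 nM

Compound 1 and compound 2 share one core and differ in a single place: methoxy in place of chloro on an aromatic carbon. That one exchange brought a 19-fold lower number from compound 1 to compound 2 (1.29 log units; beyond the scatter), so in this pair the methoxy compound is the far stronger inhibitor of cell growth.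

Compound 3 has a different core; how its core differs from that of compound 1 is not broken down here. Compound 3 and compound 2 give numbers that lie within the usual scatter of each other, so nothing separates them, while compound 1 stands well apart from both.

Compound 4 `COc1ccc2[nH]c(-c3ccccc3)c(C(c3c[nH]c4ccccc34)C3C(=O)NN=C3C)c2c1` has not yet been measured. For the measured compounds named here, it comes from compound 3 by methoxy in place of chloro on an aromatic carbon, which is the same change, in the same surroundings, as the one from compound 1 to compound 2. Going by the values given here, the only evidence for what this change does is that single earlier step, and it was large. It was, however, seen on a different core and starting from a weak compound, whereas compound 3 already gives a low number, so the full size of the earlier step need not repeat. Weighing this, compound 4 is expected to show a step of a 4.0-fold lower number from compound 3 to compound 4 (0.60 log units; beyond the scatter) in this assay, a clear improvement but smaller than the one from compound 1 to compound 2. The estimate for compound 4 is 400 nM, most likely between 80 nM and 2000 nM.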

Compound 4, half-maximal inhibitory concentration: 2700 nM
The estimate for compound 4 lay 6.8-fold (0.83 log units) below the measured number; the measured number lies above the stated range.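

In this assay, putting methoxy in place of chloro on the core of compound 3 gave a 1.7-fold higher number from compound 3 to compound 4 (0.23 log units; within the scatter), so on this core the exchange leaves the two compounds inseparable. The change therefore did not carry over from one core to the other at the same size, and the two steps clearly differ: the same change on two cores in this assay, a 19-fold lower number (1.29 log units; beyond the scatter) from compound 1 to compound 2 and a 1.7-fold higher number (0.23 log units; within the scatter) from compound 3 to compound 4, 33-fold (1.52 log units) apart, beyond the scatter of two such steps. This shows that the large step seen between the first pair cannot be taken as a general rule for methoxy in this series, but two pairs do not show which feature of the cores decides the outcome, nor how a third core would respond.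

As far as these compounds go, both pairs exchange chloro for methoxy at a single place, so it remains open whether a different group there, such as a hydroxyl, an amine, a fluoro or a longer chain like ethoxy, would also depend on the core in this way. From the compounds shown here alone, it also remains open whether the two cores would differ in the same way in any test other than this assay.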